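Furan hydroxamic acids: dropping the tolyl methyl

The compounds below may be only part of what the source reports. "The series", "measured", "known", "first", "only" and "open" are said of these compounds alone.

Measured so far in a functional assay on HepG2 cells (Homo sapiens) for antiproliferative activity, read by MTT assay, with a stated time of 48 h; a higher number here means a weaker inhibitor, a lower number a stronger inhibitor:
compound 1 `O=C(/C=C/c1ccc(/C=C/C(=O)c2cc(Cl)ccc2Cl)o1)NO` gives 48300 nM
compound 2 `Cc1ccc(C(=O)/C=C/c2ccc(/C=C/C(=O)NO)o2)cc1` gives 16000 nM
compound 3 `O=C(CCCCCCC(=O)Nc1ccccc1C(=O)NO)Nc1ccccc1` gives 63500 nM

Compound 2 stands at the lowest number of the three in this assay. Compound 1, which carries a chlorine-substituted aryl ketone on the same furan-linked chain, sits at a higher number by a margin beyond the scatter, and compound 3, built on a different core with an anilide-capped chain, sits higher still, also beyond the scatter. For the measured compounds named here, no pair of these measured compounds differs in only one place, so no measured single-point step exists to calibrate against.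

The next compound, compound 4 `O=C(/C=C/c1ccc(/C=C/C(=O)c2ccccc2)o1)NO`, is compound 2 with one change: hydrogen in place of methyl on an aromatic carbon

The change removes a single carbon from the edge of the aryl ketone and leaves everything else, including the hydroxamic acid and the doubly unsaturated furan linker, untouched. Going by the values given here, with no comparable step measured in this set, the expectation is a small one: compound 4 is expected to land close to compound 2, with a 1.3-fold higher number from compound 2 to compound 4 (0.10 log units; within the scatter) being no larger than the scatter, if anything slightly toward a weaker number. Compound 4 is therefore estimated at 20000 nM, with a range of 8000 nM to 50000 nM.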

Compound 4, half-maximal inhibitory concentration: 12100 nM
Compound 4: the middle estimate sits 1.7-fold (0.22 log units) above what was measured, within the range that was stated.
By their numbers in this assay, from the lowest: compounds 4 and 2 (each within the scatter of the next); then compounds 1 and 3 (each within the scatter of the next).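

In this assay the series now has its first step at a single place: 4-methylphenyl to phenyl gives a 1.3-fold lower number from compound 2 to compound 4 (0.12 log units; within the scatter). The methyl on an aromatic carbon para to a large group can therefore be replaced by hydrogen without a difference that this assay can separate from repeat scatter, so compound 2 and compound 4 read as equals and the methyl contributes nothing measurable to the number here. For the compounds shown here, nothing available bears on the reason for this, and the step on its own describes only this one pair of groups at this one place.

Still open, going by these compounds, is whether any other group at this place would give a step beyond the scatter, for instance a methoxy group, an amine, a carboxylic acid or a longer chain such as ethyl, since methyl and hydrogen mark only a narrow span of substituents. Compound 1 carries two chlorines and so differs from compound 4 in more than one place, which leaves the contribution of each chlorine, and of the positions they occupy, unresolved.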